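This account rests on a few compounds, and the source may have more. Where it says the series, first, only, none or still open, it means among the compounds named here.

In an ADME assay on HEK-293T cells (Homo sapiens) for cytotoxicity, read by CCK-8 assay, with a stated time of 48 h (on this read-out higher numbers stand for weaker inhibition and lower numbers for stronger inhibition), compound 1 `O=[N+]([O-])c1cccc(NC(=S)NCCNS(=O)(=O)c2ccc(-c3ccccc3OCc3ccccc3)s2)c1` gives 18300 nM. Compound 2 `COc1ccc(NC(=S)NCCNS(=O)(=O)c2sccc2-c2ccc(C)cc2Oc2ccc(O)c(O)c2)cc1` reaches only the limit of the assay, > 20000 nM. Compound 3 `O=S(=O)(NCCNC(=S)Nc1cc(C(F)(F)F)cc(C(F)(F)F)c1)c1ccc(-c2ccccc2O[C@H]2CC[C@@H](O)CC2)s1` likewise reaches only the limit, > 20000 nM. Compound 2 thus stands at the upper edge of what this set shows, and it cannot be ordered against compound 3, since both sit at the limit of > 20000 nM in this assay, at which 2 of the 3 values shown sit. Compound 4 `Cc1ccc(-c2ccsc2S(=O)(=O)NCCNC(=O)Nc2cc(Cl)cc(Cl)c2)c(Oc2ccc(O)c(O)c2)c1` differs from compound 2 by a group of 11 heavy atoms (7 carbon, 1 nitrogen, 1 oxygen, 2 chlorine; one six-membered aromatic ring of carbon only) in place of a group of 11 heavy atoms (8 carbon, 1 nitrogen, 1 oxygen, 1 sulfur; one six-membered aromatic ring of carbon only), on an amine nitrogen. Among the compounds with values here, no step between measured compounds that differ in one place is available, so a change of this kind is expected to move the read-out by none beyond the scatter, and the expected step of a number no higher from compound 2 to compound 4 (the limit leaves the size open) is small. Compound 4 is therefore expected to give about 20000 nM, with a range from 8000 nM to 50000 nM, most likely again reported only as a limit.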

Compound 4, half-maximal inhibitory concentration: 6700 nM
Estimate against measurement, compound 4: 3.0-fold (0.47 log units) above; measured number below the stated range.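

In this assay, within the data shown here, the exchange on the amine nitrogen gives an at least 2.9-fold lower number from compound 2 to compound 4 (0.47 log units; beyond the scatter), the first step at a single place in this set, so a change at this position can move the read-out beyond the scatter. The size of the step stays open, since compound 2 carries only a limit, not a number: the limit of > 20000 nM in this assay, at which 2 of the 4 values shown sit.

The compounds shown do not separate the part played by the chlorine atoms from that of the oxygen standing where sulfur stood. They also leave open how an amine or a carboxylic acid on that aromatic ring would read.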